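A few compounds are considered here, and "the series" means these few. Any claim that something is new, unique, unknown or untested is made for them only; others in the source may bear on it.

Measured compounds:
compound 1, `COc1ccc(-c2cc(=O)c3c(OC)cc(OC)cc3n2S(=O)(=O)c2ccc(C)c([N+](=O)[O-])c2)cc1` — > 51700 nM
compound 2, `COc1ccc(-c2cc(=O)c3c(OC)cc(OC)cc3n2S(=O)(=O)c2ccc(C#N)cc2)cc1` — > 17200 nM

In an ADME assay on BJ cells (Homo sapiens) for antiproliferative activity, with a stated time of 72 h (a higher number here means that more compound is needed for the effect, a lower number that less compound is needed), compound 1 gives > 51700 nM, which is a limit of the assay and not a number. In this assay compound 2 gives > 17200 nM, again a limit of the assay rather than a number. The step that the two limits leave unreadable from compound 1 to compound 2 therefore cannot be read in size or direction. Within the data shown here, compound 2 thus stands only at a limit in this assay, and the one further value shown is a limit as well: the limit of > 17200 nM in this assay, at which 1 of the 2 values shown sits, and (the limit of > 51700 nM in this assay, at which 1 of the 2 values shown sits).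

Compound 3, `COc1ccc(-c2cc(=O)c3c(OC)cc(OC)cc3n2S(=O)(=O)c2cc(F)c(F)c(F)c2)cc1`, differs from compound 2 in one place: 3,4,5-trifluorophenyl in place of 4-cyanophenyl on a sulfonyl sulfur. No measured step bears on this change in a readable way, since the single step shown is unreadable between two limits. The account therefore expects compound 3 to stay where compound 2 stands, with an expected step that the limit leaves unreadable from compound 2 to compound 3 in this assay that is not beyond the scatter, and most likely a limit again. The estimate for compound 3 in this assay is 30000 nM, with a range from 10000 nM to 100000 nM.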

Compound 3, half-maximal effective concentration: > 65500 nM
Compound 3: a limit, no number (the forecaster's own chance of this, stated with the estimate: 80%); at least 2.1-fold (0.33 log units) between middle value and limit.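

In this assay compound 3 gives > 65500 nM, which is a limit of the assay and not a number. Compound 1 and compound 2 also stand only at limits, so no step among these three compounds can be read in size or direction. The compounds shown leave open whether any group on the sulfonyl sulfur gives a measurable value in this assay.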